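A few compounds are considered here, and "the series" means these few. Any claim that something is new, unique, unknown or untested is made for them only; others in the source may bear on it.

In a functional assay on blood (Homo sapiens), with a stated time of 60 min, in the presence of a further agent that is not named here (on this read-out higher numbers stand for an effect only at larger amounts of compound and lower numbers for an effect already at smaller amounts), compound 1 `Nc1ccccc1NC(=O)C1(S(=O)(=O)c2ccc(Oc3ccc(OC(F)(F)F)cc3)cc2)CCC2(CCNCC2)C1` gives 900 nM. Compound 2 `CN(C)S(=O)(=O)NC(=O)C1(S(=O)(=O)c2ccc(Oc3ccc(OC(F)(F)F)cc3)cc2)CCC2(CCNCC2)C1` gives > 15000 nM, which is a limit of the assay and not a number. Compound 3 `CS(=O)(=O)NC(=O)C1(S(=O)(=O)c2ccc(Oc3ccc(OC(F)(F)F)cc3)cc2)CCC2(CCNCC2)C1` carries methyl in place of dimethylamino on a sulfonyl sulfur. For the measured compounds named here, the one measured step that bears on this is large and beyond the scatter, an at least 16-fold higher number from compound 1 to compound 2 (1.22 log units; beyond the scatter), and it replaced 2-aminophenyl with dimethylsulfamoyl on an amide-type nitrogen. Compound 3 keeps a sulfonyl on that nitrogen, so the large step is not expected to be undone. The expected change in this assay is a number no higher from compound 2 to compound 3 (the limit leaves the size open), which would be no step beyond the scatter. The estimate for compound 3 is 15000 nM, with a range from 4000 nM to 40000 nM.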

Compound 3, half-maximal effective concentration: > 15000 nM
Compound 3 was reported as a limit (the forecaster's own chance of this, stated with the estimate: 65%); the middle value sits exactly at the limit.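

Methylsulfonyl on the amide-type nitrogen behaves like dimethylsulfamoyl: in this assay, putting it in place of 2-aminophenyl gives an at least 16-fold higher number from compound 1 to compound 3 (1.22 log units; beyond the scatter). The large step seen with compound 2 is therefore not tied to the dimethylamino on the sulfonyl sulfur. The step between compound 2 and compound 3 cannot be read, since both values are limits of the assay: the limit of > 15000 nM in this assay, at which 2 of the 3 values shown sit.

Going by these compounds, how far compound 2 and compound 3 actually lie past that limit stays open. So does whether a plain phenyl or an aminoethyl chain on that nitrogen would give a measurable number.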